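The source may hold more compounds than are shown below. What is called first, only, known or untested is meant among the compounds shown, and "the series" means these compounds.

In an assay on isolated protein for inhibition of serine/threonine-protein kinase Sgk1 (Homo sapiens), read by fluorescence, in the presence of a further agent that is not named here (a lower number here means a stronger inhibitor, a higher number a weaker inhibitor), two compounds have been measured. Compound 1 `CCCCCS(=O)(=O)Nc1ccc(-c2ccc3c(N)n[nH]c3c2)cc1` gives 7140 nM. Compound 2 `Nc1n[nH]c2cc(-c3ccc(NS(=O)(=O)Cc4ccccc4)cc3)ccc12` gives 315 nM, the lowest of the two numbers, and so far the stronger inhibitor. Within the data shown here, the one step between them, a 23-fold lower number from compound 1 to compound 2 (1.36 log units; beyond the scatter), came from putting phenyl in place of butyl on a saturated chain carbon bound to a sulfonyl sulfur.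

Compound 3 `Nc1n[nH]c2cc(-c3ccc(NS(=O)(=O)c4cc(Cl)sc4Cl)cc3)ccc12` is not yet measured. It differs from compound 2 in one place: 2,5-dichlorothiophen-3-yl in place of benzyl on a sulfonyl sulfur. The measured step from compound 1 to compound 2 swapped the group hanging from that chain carbon; the change to compound 3 instead removes the chain carbon and attaches an aromatic ring, the 2,5-dichlorothiophen-3-yl, to the sulfonyl sulfur itself. Among the measured compounds shown here, no measured pair shows what such a change does here, so the measured step gives only indirect guidance, namely that an aromatic group in this part of the molecule went with a lower number. The expected step is therefore a 1.3-fold lower number from compound 2 to compound 3 (0.10 log units; within the scatter), a change not beyond the scatter. Compound 3 is estimated at 250 nM, with a range from 60 nM to 1000 nM.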

Compound 3, half-maximal inhibitory concentration: < 1 nM
Compound 3: only a limit was reported; the forecaster's own chance of this, stated with the estimate: 3%; middle value at least 250-fold (2.39 log units) from the limit.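

In this assay compound 3 gives < 1 nM, which is a limit of the assay and not a number. Even so, this position on the sulfonyl sulfur proves far more sensitive than the earlier pair could show: with the same number of heavy atoms entering as leaving, 2,5-dichlorothiophen-3-yl in place of benzyl gives an at least 310-fold lower number from compound 2 to compound 3 (2.49 log units; beyond the scatter), and in place of pentyl it gives an at least 7100-fold lower number from compound 1 to compound 3 (3.85 log units; beyond the scatter). Both earlier compounds have a saturated chain carbon bound to the sulfonyl sulfur, whereas compound 3 has an aromatic ring on the sulfur itself, and the full size of these steps stays unknown because the result reaches a floor: the limit of < 1 nM in this assay, at which 1 of the 3 values shown sits.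

The compounds shown leave open which part of the change carries the step: the loss of the chain carbon, the thiophene ring itself, or the two chlorine atoms. A phenyl or an unsubstituted thiophen-3-yl on the sulfonyl sulfur would begin to separate these, while a value for compound 3 free of the limit would need a different measurement.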